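A few compounds are considered here, and "the series" means these few. Any claim that something is new, unique, unknown or untested is made for them only; others in the source may bear on it.

Working notes on the series.

Compound 1 `COc1cc(Nc2ncnc3c(NC(=O)Nc4ccc(C)c(C)c4)cccc23)cc(OC)c1` is the reference point. Among the measured compounds shown here, in a functional assay on RT-112 cells (Homo sapiens) for antiproliferative activity, read by MTT assay, with a stated time of 72 h (on this read-out lower numbers stand for stronger inhibition of growth and higher numbers for weaker inhibition of growth), compound 1 gives 8.8 nM, the lowest of the three numbers so far. Compound 2 `COc1cc(Nc2ncnc3c(NC(=O)Nc4cc(Cl)cc(Cl)c4)cccc23)cc(OC)c1` gives 30.2 nM in this assay, and compound 3 `COc1cc(Nc2ncnc3c(NC(=O)Nc4cc(Cl)c(Cl)cc4Cl)cccc23)cc(OC)c1` gives 4890 nM. The two measured changes both swap the ring that sits on the amide-type nitrogen: a 3.4-fold higher number from compound 1 to compound 2 (0.54 log units; beyond the scatter), and a 560-fold higher number from compound 1 to compound 3 (2.74 log units; beyond the scatter); between those two, a 160-fold higher number from compound 2 to compound 3 (2.21 log units; beyond the scatter).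

Compound 4 `COc1cc(Nc2ncnc3c(NC(=O)c4cc(=O)c5ccccc5o4)cccc23)cc(OC)c1` changes a different place. Relative to compound 1 the difference is a group of 11 heavy atoms (9 carbon, 2 oxygen; one six-membered aromatic ring of carbon only, one six-membered aromatic ring with 1 hetero atom) in place of a group of 9 heavy atoms (8 carbon, 1 nitrogen; one six-membered aromatic ring of carbon only), on a carbonyl carbon. For the measured compounds named here, no measured step touches the carbonyl carbon, so the three steps bear on this change only indirectly; what they show is that every departure from compound 1 so far has raised the number, once modestly and once greatly. A step beyond the scatter toward a higher number is therefore expected, of a size closer to the modest one, as a 6.8-fold higher number from compound 1 to compound 4 (0.83 log units; beyond the scatter). The expected value for compound 4 in this assay is 60 nM, with a range from 10 nM to 500 nM.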

Compound 4, concentration for 50% growth inhibition: > 20000 nM
Compound 4 gave a limit, no number; the forecaster's own chance of this, stated with the estimate: 5%; middle value at least 330-fold (2.52 log units) away from the limit.
By their numbers in this assay, from the lowest: compound 1; then compound 2; then compound 3. At a limit, above all of these: compound 4.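

In this assay compound 4 stands at a limit of the assay, not at a number: the limit of > 20000 nM in this assay, at which 1 of the 4 values shown sits. With the group of 11 heavy atoms in place of the aryl-bearing amino group on the carbonyl carbon, the steps read an at least 2200-fold higher number from compound 1 to compound 4 (3.35 log units; beyond the scatter), an at least 660-fold higher number from compound 2 to compound 4 (2.82 log units; beyond the scatter) and an at least 4.0-fold higher number from compound 3 to compound 4 (0.61 log units; beyond the scatter). Among the compounds shown here, the earlier steps all kept the amino nitrogen on the carbonyl carbon and changed only its ring, so this is the first sign that replacing the whole group at this place can carry the number past even that of the trichlorophenyl compound 3.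

Compound 4 changes the nitrogen and the ring system in one step, so the compounds shown cannot say which of the two accounts for the result. From the compounds shown here alone, how a plain phenyl or a benzylamino group on the same carbonyl carbon would read remains open.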